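Nitro in place of cyano on the anilide ring of compound 2

The source may report more compounds than this note shows. Statements on the series, on what has been measured and on what is new or still open speak of the compounds shown alone.

Compound 1 `CC(CS(=O)(=O)c1cc(C(F)(F)F)cc(C(F)(F)F)c1)C(=O)Nc1ccc([N+](=O)[O-])c(C(F)(F)F)c1` and compound 2 `CC(CS(=O)(=O)c1cc(C(F)(F)F)cc(C(F)(F)F)c1)C(=O)Nc1ccc(C#N)cc1C(F)(F)F` share the same core and differ only in the arrangement of substituents on the anilide ring. In a functional assay on LNCaP cells (Homo sapiens) for antiproliferative activity, read by MTT assay, with a stated time of 96 h (a higher number here means a weaker inhibitor, a lower number a stronger inhibitor), compound 2 gives 9560 nM, and compound 1 at 12200 nM lies within the scatter of that figure, so the two are not distinguishable. Compound 3 `CC(CS(=O)(=O)c1cc(C(F)(F)F)cc(C(F)(F)F)c1)C(=O)Nc1ccc([N+](=O)[O-])cc1C(F)(F)F` differs from compound 2 by nitro in place of cyano on an aromatic carbon. Within the data shown here, no measured pair shows this change; a step in this assay of no more than the scatter is expected, in either direction. Compound 3 is therefore estimated at 11000 nM, between 5000 nM and 25000 nM. The estimated step is a 1.2-fold higher number from compound 2 to compound 3 (0.06 log units; within the scatter), expected to stay within the scatter.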

Compound 3, half-maximal inhibitory concentration: 3080 nM
The estimate for compound 3 lay 3.6-fold (0.55 log units) above the measured number; the whole stated range lies above it.
By their numbers in this assay, from the lowest: compound 3; then compounds 2 and 1 (each within the scatter of the next).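

Among these compounds, replacing cyano with nitro para to a large group gives a 3.1-fold lower number from compound 2 to compound 3 (0.49 log units; beyond the scatter) in this assay, the first single-place change and the first step beyond the scatter. This position therefore responds to the identity of its group, which compounds 1 and 2 alone could not show. No available measurement explains the step.

On these data alone, whether an amine or a carboxylic acid at this position would give a lower or higher number remains open. A single pair also leaves open whether the step carries over to other substituents on the shared core.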